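Thiophene regioisomer swap at the saturated ring carbon

A few compounds are considered here, and "the series" means these few. Any claim that something is new, unique, unknown or untested is made for them only; others in the source may bear on it.

Two members of this series have been measured in an assay on membranes from CHO cells for displacement of a labelled ligand from adenosine receptor A1 (Homo sapiens), read by scintillation counting, with a stated time of 60 min, tested at 1 uM; on this read-out lower numbers stand for less inhibition and higher numbers for more inhibition at the one concentration tested (going by the name of the read-out). Compound 1 `CCN(CC)C(=O)C1=C(C)NC(=O)NC1c1ccsc1` gives 11% in this assay. Compound 2 `CC1=C(C(=O)OC2CCCCC2)C(c2cccs2)NC(=O)N1` gives 7% in this assay; its number and that of compound 1 lie within the scatter of one another, so no ordering between them follows. Compound 3 `CC1=C(C(=O)OC2CCCCC2)C(c2ccsc2)NC(=O)N1` differs from compound 2 in one place: thiophen-3-yl in place of thiophen-2-yl on a saturated ring carbon. Going by the values given here, no measured pair isolates this change, so the step from compound 2 to compound 3 is expected to stay within the scatter, a number 3 percentage points higher from compound 2 to compound 3 (within the scatter). Compound 3 is estimated at 10% in this assay, between 0% and 25%.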

Compound 3, a percentage reported as inhibition, at one concentration (the size of the read-out at that concentration, not a potency): 8%
For compound 3 the middle estimate is 2 percentage points above the measured one, and the stated range covers the measured number.
By their numbers in this assay, from the lowest: compounds 2, 3 and 1 (each within the scatter of the next).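

Thiophen-3-yl in place of thiophen-2-yl on the saturated ring carbon gives a number 1 percentage points higher from compound 2 to compound 3 (within the scatter) in this assay, so this swap of thiophene attachment leaves no readable change at this position. Going by these compounds alone, compound 3 also gives the first one-place comparison at the carbonyl carbon, where cyclohexyloxy in place of diethylamino gives a number 3 percentage points lower from compound 1 to compound 3 (within the scatter). No supporting data bear on either step.

The compounds shown leave open whether a phenyl ring on the saturated ring carbon would separate from these numbers. The same holds for a carboxylic acid at the carbonyl carbon.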